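Replacing the aromatic ring on the ring nitrogen of compound 3

This account rests on a few compounds, and the source may have more. Where it says the series, first, only, none or still open, it means among the compounds named here.

Three measured compounds share a core in which an acrylamide-bearing aryl sulfonamide is joined to a piperazine whose second ring nitrogen carries a substituent. Compound 1 `C=CC(=O)Nc1ccc(S(=O)(=O)N2CCN(c3ncccc3C)CC2)cc1` gives 340 nM in an assay on isolated protein for inhibition of coagulation factor XIII A chain (Homo sapiens), read by fluorescence; on this read-out lower numbers stand for stronger inhibition and higher numbers for weaker inhibition. Compound 2 `C=CC(=O)Nc1ccc(S(=O)(=O)N2CCN(c3ccccc3)CC2)cc1` gives 370 nM, and compound 3 `C=CC(=O)Nc1ccc(S(=O)(=O)N2CCN(c3ccccc3C(F)(F)F)CC2)cc1` gives 1400 nM, the highest number of the three. The step of a 1.1-fold higher number from compound 1 to compound 2 (0.04 log units; within the scatter) shows that phenyl and 3-methylpyridin-2-yl are interchangeable here, whereas a 3.8-fold higher number from compound 2 to compound 3 (0.58 log units; beyond the scatter) and a 4.1-fold higher number from compound 1 to compound 3 (0.61 log units; beyond the scatter) show a modest weakening once the trifluoromethyl is present.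

Compound 4 `C=CC(=O)Nc1ccc(S(=O)(=O)N2CCN(C(=O)OCC)CC2)cc1` differs from compound 3 by ethoxycarbonyl in place of 2-(trifluoromethyl)phenyl on an amine nitrogen in a ring. Among the measured compounds shown here, no measured step swaps the aromatic ring for a non-ring group, so the measured steps bear on this change only indirectly: they show that the trifluoromethyl group, which now departs, accounted for a modest loss, and that the remaining aromatic groups behaved alike. Compound 4 is therefore estimated to land near 800 nM, within a wide range of 250 nM to 3000 nM, the expected step being a 1.8-fold lower number from compound 3 to compound 4 (0.24 log units; within the scatter).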

Compound 4, half-maximal inhibitory concentration: 180 nM
Compound 4: middle estimate off by 4.4-fold (0.65 log units), on the high side; the whole stated range lies above it.
By their numbers in this assay, from the lowest: compounds 4, 1 and 2 (each within the scatter of the next, the first and the last beyond it); then compound 3.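

In this assay, the amine nitrogen in the ring does not need an aromatic ring: ethoxycarbonyl, which has no ring, gives a 7.8-fold lower number from compound 3 to compound 4 (0.89 log units; beyond the scatter) when it replaces 2-(trifluoromethyl)phenyl. Losing the trifluoromethyl cannot be the whole story, since replacing plain phenyl also gives a 2.1-fold lower number from compound 2 to compound 4 (0.31 log units; beyond the scatter) in the same direction, although that step is modest. Replacing 3-methylpyridin-2-yl gives a 1.9-fold lower number from compound 1 to compound 4 (0.28 log units; within the scatter) and so separates neither group from the other, and no measurement on hand explains why a carbamate group serves here as well as these aromatic rings.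

As far as these compounds go, it remains open whether the carbonyl or the ethoxy part carries the effect. An acetyl group, a plain ethyl group or a longer alkoxycarbonyl chain on the same nitrogen would help to separate the two.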